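A few compounds are considered here, and "the series" means these few. Any claim that something is new, unique, unknown or untested is made for them only; others in the source may bear on it.

Working notes on the dithiocarbamate series in an ADME assay on HeLa cells (Homo sapiens) for cytotoxicity, read by MTT assay, with a stated time of 24 h; on this read-out higher numbers stand for weaker inhibition and lower numbers for stronger inhibition. Three members of the set have been run so far. Compound 1 `CCOC(=O)N1CCN(C(=S)SC(=S)N(C)C)CC1` gives 530000 nM. Compound 2 `CN(C)C(=S)SC(=S)N1CCN(C(=O)c2ccco2)CC1` gives 2380000 nM. Compound 3 `CCSC(=S)N1CCN(C(=S)SC(=S)N(C)C)CC1` gives 4480000 nM, the highest number of the three; its gap to compound 2 sits within the scatter, while its gap to compound 1 is beyond it. The measured steps are a 4.5-fold higher number from compound 1 to compound 2 (0.65 log units; beyond the scatter), an 8.5-fold higher number from compound 1 to compound 3 (0.93 log units; beyond the scatter) and a 1.9-fold higher number from compound 2 to compound 3 (0.27 log units; within the scatter).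

Compound 4 `CN(C)C(=S)SC(=S)N1CCN(C(=S)SCCCC#N)CC1` has not yet been run. It differs from compound 3 by cyanomethyl in place of hydrogen on a saturated chain carbon, two bonds along the chain from a sulfur. None of the three measured steps touches this part of the molecule: each of them replaces the whole group on the ring nitrogen (ethoxycarbonyl, furan-2-carbonyl, ethylsulfanylthiocarbonyl) rather than lengthening the ethyl chain, so no shown step bears directly on the change. The two groups that share the thiocarbonyl-sulfur chain attachment, compound 3 and compound 4, thus stand without a precedent in this set. With nothing in the data pointing either way, no step beyond the scatter is expected in this assay; the estimated step is a 1.0-fold higher number from compound 3 to compound 4 (0.00 log units; within the scatter). For compound 4 the number is expected near 4500000 nM, with a range from 1500000 nM to 13000000 nM.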

Compound 4, half-maximal inhibitory concentration: > 5000000 nM
Compound 4: a limit, no number (the forecaster's own chance of this, stated with the estimate: 25%); middle value at least 1.1-fold (0.04 log units) away from the limit.
By their numbers in this assay, from the lowest: compound 1; then compounds 2 and 3 (each within the scatter of the next). At a limit, above all of these: compound 4.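

In this assay compound 4 gives > 5000000 nM, which is a limit of the assay and not a number. Going from ethylsulfanyl to (3-cyanopropyl)sulfanyl gives an at least 1.1-fold higher number from compound 3 to compound 4 (0.04 log units; that floor lies within the scatter), and as that floor lies within the scatter, the result does not establish that the cyanomethyl change moves the number at all, only that this extension of the chain on sulfur does not bring the number down to a value that can be read. Unlike the earlier steps, which replace the whole group on the ring nitrogen, this one alters the chain on sulfur alone, and it yields the only member of the set that stands at a limit: the limit of > 5000000 nM in this assay, at which 1 of the 4 values shown sits.

The compounds shown do not separate the nitrile from the added chain length, and a butyl group on the sulfur or a 3-aminopropyl group, with an amine at the chain end, would tell the two apart. As far as these compounds go, how far compound 4 truly lies from compound 3 also remains open, as does whether a longer nitrile-bearing chain on the sulfur would behave in the same way.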